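A few compounds are considered here, and "the series" means these few. Any claim that something is new, unique, unknown or untested is made for them only; others in the source may bear on it.

Working notes on the series, all read in a functional assay on OVCAR-3 cells (Homo sapiens) for cytotoxicity, read by MTT assay, with a stated time of 6 days; a lower number here means a stronger inhibitor, a higher number a weaker inhibitor. Compound 1 (`CC(=O)N[C@@H](CSC(=O)Nc1ccc(Br)cc1)C(=O)O`) has no number yet: compound 1 reaches only a limit, > 200000 nM. Compound 2 (`CC(=O)N[C@@H](CSC(=O)Nc1ccc(C(F)(F)F)cc1[N+](=O)[O-])C(=O)O`), with its trifluoromethyl and nitro groups, also returns only a limit, > 200000 nM. Compound 3 (`COc1ccc(OC)c(NC(=O)SC[C@H](NC(C)=O)C(=O)O)c1`), with its two methoxy groups, likewise returns only a limit, > 200000 nM. The measured set therefore comes down to the limit of > 200000 nM in this assay, at which 3 of the 3 values shown sit. For the measured compounds named here, compound 1 cannot be ranked against compound 2 or compound 3, and no measured step is available to size a substituent change.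

Compound 4 (`CC(=O)N[C@@H](CSC(=O)Nc1ccc(I)cc1)C(=O)O`) remains unmeasured. It is iodo in place of bromo on an aromatic carbon, para to a large group on the six-membered aromatic ring: iodo in place of bromo on an aromatic carbon. All three measured compounds, with different substituents on that ring, end at the same limit, and this swap is a single-atom exchange at one place. No shift beyond the usual scatter is expected, and the most likely report is another limit rather than a number. The estimated change is a number no higher from compound 1 to compound 4 (the limit leaves the size open), which is expected to stay within the scatter. For compound 4 the expected value is 200000 nM, with an estimated range of 100000 nM to 300000 nM.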

Compound 4, half-maximal inhibitory concentration: > 200000 nM
Compound 4: only a limit was reported (the forecaster's own chance of this, stated with the estimate: 80%); the middle value lies on the limit itself.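

Compound 1 and compound 4 both end at a limit, and the step of iodo in place of bromo between them cannot be read. The whole set stands at one place: the limit of > 200000 nM in this assay, at which 4 of the 4 values shown sit.

The compounds shown leave open whether any substituent on this ring gives a measurable number in this assay.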